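The source may hold more compounds than are shown below. What is called first, only, known or untested is meant among the compounds shown, and "the series" means these compounds.

Compound 1 `CNc1nccc(N2CC[C@H](NC(=O)Nc3ccc(Cl)c(C(F)(F)F)c3)C2)n1` and compound 2 `CCNc1nccc(N2CC[C@H](NC(=O)Nc3ccc(Cl)c(C(F)(F)F)c3)C2)n1` share one core. In a physicochemical assay for solubility, measured as kinetic solubility (a higher number here means a more soluble compound, a lower number a less soluble compound), compound 1 gives 22200 nM, and compound 2 gives 29900 nM. The change between them, (hydrogen in place of methyl on a saturated chain carbon bound to a nitrogen on an aromatic ring), made a 1.3-fold lower number from compound 2 to compound 1 (0.13 log units; within the scatter). Compound 3 `CCN1CCN(Cc2ccc(NC(=O)N[C@H]3CCN(c4ccnc(NC)n4)C3)cc2C(F)(F)F)CC1` carries a different core, and how its core differs from that of compound 2 is not broken down here; in this assay compound 3 gives 132000 nM, the step being a 5.9-fold higher number from compound 1 to compound 3 (0.77 log units; beyond the scatter). Compound 4 `CNc1nccc(N2CC[C@H](NC(=O)Nc3ccc(CN4CCN(C)CC4)c(C(F)(F)F)c3)C2)n1` is related to compound 3 by hydrogen in place of methyl on a saturated chain carbon bound to an amine nitrogen in a ring. This is the same kind of change as that from compound 2 to compound 1, though the place differs: there the carbon was bound to a nitrogen on an aromatic ring, here to an amine nitrogen in a ring. Because a 1.3-fold lower number from compound 2 to compound 1 (0.13 log units; within the scatter) stayed within the scatter, compound 4 is expected to show a 1.1-fold lower number from compound 3 to compound 4 (0.04 log units; within the scatter). Compound 4 is estimated at 120000 nM, between 50000 nM and 300000 nM.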

Compound 4, solubility: 67500 nM
The estimate for compound 4 lay 1.8-fold (0.25 log units) above the measured number; the measured number falls inside the stated range.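

In this assay, ethyl to methyl on the 4-ethylpiperazin-1-yl group gives a 2.0-fold lower number from compound 3 to compound 4 (0.29 log units; within the scatter) and the same kind of change at the other place gave a 1.3-fold lower number from compound 2 to compound 1 (0.13 log units; within the scatter) so both steps stay within the scatter, whereas (4-methylpiperazin-1-yl)methyl in place of chloro gives a 3.0-fold higher number from compound 1 to compound 4 (0.48 log units; beyond the scatter) and so lies beyond it. Going by these compounds alone, this shows only that the change stayed within the scatter in these two pairs, at two different places on two cores; it does not show that it would do so on any further core. No measurement at hand explains either step.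

The compounds shown leave open whether a longer chain, as in 4-propylpiperazin-1-yl, would also stay within the scatter. They also leave open how morpholin-4-yl in place of 4-methylpiperazin-1-yl would compare.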